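The source may report more compounds than this note shows. Statements on the series, on what has been measured and on what is new or still open speak of the compounds shown alone.

Compound 1, `Fc1ccc2nc(-c3cn[nH]c3)n(C3CC3)c2c1`: 1670 nM
Compound 2, `Fc1ccc2nc(-c3cncs3)n(C3CC3)c2c1`: 4520 nM
Compound 3, `CCc1ncncc1-c1nc2cc(F)c(F)cc2n1C1CC1`: 3330 nM

These three compounds were tested in an ADME assay on cells for inhibition of cytochrome P450 11B1, mitochondrial (Homo sapiens), read by HPLC, with a stated time of 60 min; on this read-out higher numbers stand for weaker inhibition and lower numbers for stronger inhibition. Compound 3 gives 3330 nM, the second highest of the three numbers; its gap to compound 2 and its gap to compound 1 both lie within the usual scatter, so no order among them can be claimed. Within the data shown here, the only one-place step that is resolved runs between compound 1 and compound 2: a 2.7-fold higher number from compound 1 to compound 2 (0.43 log units; beyond the scatter), where a 1,3-thiazol-5-yl replaces a 1H-pyrazol-4-yl on an aromatic carbon.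

Compound 4, `CNc1ncncc1-c1nc2cc(F)c(F)cc2n1C1CC1`, differs from compound 3 in one place: methylamino in place of ethyl on an aromatic carbon. Among the measured compounds shown here, no measured step touches this part of the shared core, and the one resolved step concerns a different position, so it offers no guide here. With no evidence either way, the expectation is that the change from compound 3 to compound 4 brings no step beyond the scatter, written as a 1.1-fold lower number from compound 3 to compound 4 (0.05 log units; within the scatter). For compound 4 in this assay the estimate is 3000 nM, with a range from 1000 nM to 9000 nM.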

Compound 4, half-maximal inhibitory concentration: 390 nM
For compound 4 the middle estimate is 7.7-fold (0.89 log units) above the measured one; the measured number lies below the stated range.
By their numbers in this assay, from the lowest: compound 4; then compounds 1, 3 and 2 (each within the scatter of the next, the first and the last beyond it).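

In this assay, the place on the six-membered aromatic ring with 2 nitrogen proves sensitive to what sits on it: methylamino in place of ethyl gives an 8.5-fold lower number from compound 3 to compound 4 (0.93 log units; beyond the scatter). Each group has 2 heavy atoms, so the step comes without a change in that count; what differs is a nitrogen in place of a carbon, with 1 hydrogen-bond donor and 1 hydrogen-bond acceptor entering where ethyl has 0 of each. No measurement at hand says why the number falls.

As far as these compounds go, it remains open whether the nitrogen alone accounts for the step or whether its methyl also plays a part; a plain amine and a dimethylamino group at this place would help separate the two. How a methoxy group would compare is open as well.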